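This account rests on a few compounds, and the source may have more. Where it says the series, first, only, none or still open, it means among the compounds named here.

Compound 1 `N#C/C(=C\c1ccccc1OS(=O)(=O)c1ccccc1[N+](=O)[O-])C(=O)Nc1nnc(Cc2ccccc2)s1`: 10%
Compound 2 `N#C/C(=C\c1ccccc1OS(=O)(=O)c1ccc(Cl)cc1)C(=O)Nc1nnc(Cc2ccccc2)s1`: 25%
Compound 3 `N#C/C(=C\c1ccccc1OS(=O)(=O)c1ccc(F)cc1)C(=O)Nc1nnc(Cc2ccccc2)s1`: 6%

All three values come from an ADME assay on HEK-293T cells (Homo sapiens) for inhibition, read by CCK-8 assay, with a stated time of 48 h, tested at 20 uM; on this read-out lower numbers stand for less inhibition of growth and higher numbers for more inhibition of growth at the one concentration tested. Compound 1 sits at the low end of these numbers. Its nearest neighbour shows a number 4 percentage points lower from compound 1 to compound 3 (within the scatter), and its furthest shows a number 15 percentage points higher from compound 1 to compound 2 (beyond the scatter).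

Compound 4 `N#C/C(=C\c1ccccc1OS(=O)(=O)c1ccccc1[N+](=O)[O-])C(=O)Nc1nnc(Cc2ccc(F)cc2)s1` keeps the group on the sulfonyl sulfur of compound 1 and changes the benzyl: fluoro in place of hydrogen on an aromatic carbon. This is fluoro in place of hydrogen on an aromatic carbon, or benzyl to 4-fluorobenzyl. For the measured compounds named here, no measured step covers this site, since all three lie on the group on the sulfonyl sulfur. The nearest guides are indirect. Exchanging one halogen for another gave a number 19 percentage points lower from compound 2 to compound 3 (beyond the scatter), and introducing a fluoro-bearing ring gave a number 4 percentage points lower from compound 1 to compound 3 (within the scatter). On that thin basis, no step beyond the scatter is expected in this assay. The estimated step is a number 2 percentage points higher from compound 1 to compound 4 (within the scatter). Compound 4 is expected at 12%, with an estimated range of 3% to 25%.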

Compound 4, percent growth inhibition at one concentration: 6%
Estimate against measurement, compound 4: 6 percentage points above; the measured number falls inside the stated range.
By their numbers in this assay, from the lowest: compounds 3, 4 and 1 (each within the scatter of the next); then compound 2.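

In this assay, the first reading away from the group on the sulfonyl sulfur, benzyl to 4-fluorobenzyl gives a number 4 percentage points lower from compound 1 to compound 4 (within the scatter), so this change does not separate the two compounds. With the 2-nitrophenyl group held fixed, fluoro in place of hydrogen on this aromatic carbon has left the number within the scatter, whereas the halogen exchange on the group on the sulfonyl sulfur gave a number 19 percentage points lower from compound 2 to compound 3 (beyond the scatter), a step beyond it. Nothing measured here explains this outcome.

Going by these compounds, whether a methoxy group, an amine or a carboxylic acid at the same place on the benzyl ring would give a step beyond the scatter remains open. Also open, on these data alone, is whether the 4-fluorobenzyl change would read the same with the 4-chlorophenyl group of compound 2 on the sulfonyl sulfur.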